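Longer Chain, Same Headgroup: Predicting Compound 3

This account rests on a few compounds, and the source may have more. Where it says the series, first, only, none or still open, it means among the compounds named here.

Of the compounds shown here, two have been measured here. Compound 1 `CCCCCCCCCCCCCCNC(=O)[C@@H](N)[C@@H](C)O` carries a free amine on its headgroup and a long fatty chain on the amide nitrogen; in a functional assay on MCF7 cells (Homo sapiens) for cytotoxicity, read by MTT assay, with a stated time of 48 h (a higher number here means a weaker inhibitor, a lower number a stronger inhibitor), compound 1 gives 10700 nM. Compound 2 `CCCCCCCCNC(=O)[C@@H](NC(=O)c1ccccc1)[C@@H](C)O` differs in both parts, with a benzoyl group capping the amine and a shorter chain on the amide nitrogen. In this assay compound 2 gives 111000 nM, the highest of the two numbers, and the gap to compound 1 lies beyond the usual scatter. The two differ in two places. No single change can be pinned to that gap.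

Compound 3 `CCCCCCCCCCCCCCNC(=O)[C@@H](NC(=O)c1ccccc1)[C@@H](C)O` keeps the benzoyl cap of compound 2 but takes the chain length of compound 1: hexyl in place of hydrogen on a saturated chain carbon, eight bonds along the chain from an amide-type nitrogen. Within the data shown here, the only change in compound 3 is the longer chain. Given that compound 1, the one measured compound with this chain length, gives 10700 nM, the step of a 3.2-fold lower number from compound 2 to compound 3 (0.50 log units; beyond the scatter) is expected to be a moderate move toward stronger inhibition. For compound 3 the value in this assay is therefore estimated at 35000 nM, within a range from 10000 nM to 110000 nM.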

Compound 3, half-maximal inhibitory concentration: 24800 nM
For compound 3 the middle estimate is 1.4-fold (0.15 log units) above the measured one; low and high end bracket the measured number.
By their numbers in this assay, from the lowest: compound 1; then compound 3; then compound 2.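

With the benzoyl cap held fixed, hexyl in place of hydrogen on a saturated chain carbon, eight bonds along the chain from an amide-type nitrogen, gives a 4.5-fold lower number from compound 2 to compound 3 (0.65 log units; beyond the scatter) in this assay, so the longer chain alone moves this read-out toward stronger inhibition. With the longer chain held fixed, benzoyl in place of hydrogen on an amine nitrogen gives a 2.3-fold higher number from compound 1 to compound 3 (0.37 log units; beyond the scatter) and moves the read-out toward weaker inhibition, so each of the two changes that could not be told apart before now has a size of its own, and both steps lie beyond the usual scatter. Nothing on hand explains why either change acts as it does.

The compounds shown leave open whether the chain step keeps its size on the free amine, which a compound joining that amine to the shorter chain of compound 2 would test. They also leave open whether a still longer chain continues the trend, and whether a smaller cap such as acetyl in place of benzoyl costs as much inhibition.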